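The source may hold more compounds than are shown below. What is called first, only, known or untested is meant among the compounds shown, and "the series" means these compounds.

Compound 1, `Cc1ccc(-c2nc3cccnc3o2)cc1`: in a functional assay on the whole organism for inhibition, with Rattus norvegicus as the target, at a dose of 30 mg/kg (a higher number here means more inhibition at the dose given (going by the name of the read-out), a lower number less inhibition), compound 1 gives 0%.
Compound 2, `N#Cc1cccc(F)c1-c1nc2ncccc2o1`: in this assay compound 2 gives 50%.

Of the two measured compounds, compound 1 holds the lowest number, and compound 2 stands above it by a gap that is beyond the usual scatter of this kind of measurement.

The next compound to be tested is compound 3, `Fc1ccc(-c2nc3cccnc3o2)cc1`. Compared with compound 1 the change is fluoro in place of methyl on an aromatic carbon, on an aromatic carbon of a six-membered aromatic ring of carbon only. Going by the values given here, no two measured compounds differ by exactly this swap, so there is no measured step to lean on. Compound 2 does carry a fluoro, but it also carries a nitrile, so its value shows only what that combination gives.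

The step from compound 1 to compound 3 is therefore expected to be small, a number 10 percentage points higher from compound 1 to compound 3 (within the scatter), if anything upward but likely within the scatter. Compound 3 is estimated at 10%, with a range from 0% to 35%.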

Compound 3, a percentage reported as inhibition, in the whole organism at one dose (the size of the read-out at that dose, not a potency): 27%
For compound 3 the middle estimate is 17 percentage points below the measured one, and the stated range covers the measured number.
By their numbers in this assay, from the lowest: compound 1; then compound 3; then compound 2.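

Putting fluoro in place of methyl at this one place changes the result in this assay, with a number 27 percentage points higher from compound 1 to compound 3 (beyond the scatter). This shows that the position para to a group of 9 heavy atoms is not indifferent to what sits on it, even though both groups count a single heavy atom and neither has a hydrogen-bond donor or acceptor. What lies behind the rise cannot be told, as no measurement here speaks to a cause.

As far as these compounds go, whether a chlorine atom, a methoxy group or an amine at this same place would raise the number further remains open. Also open, from the compounds shown here alone, is what fluoro would give at another place on this ring, with the rest of compound 3 unchanged.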